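Sulfonyl aryl swaps on the trifluoromethyl hydroxy amide series

This account rests on a few compounds, and the source may have more. Where it says the series, first, only, none or still open, it means among the compounds named here.

In a functional assay (Cavia porcellus) with sulfonylurea receptors; K-ATP channels (Homo sapiens) as the target (on this read-out lower numbers stand for stronger inhibition and higher numbers for weaker inhibition), compound 3 `CC(O)(C(=O)Nc1ccc(S(=O)(=O)c2ccccn2)cc1)C(F)(F)F` gives 600 nM, the lowest of the three numbers measured. Compound 1 `CC(O)(C(=O)Nc1ccc(S(=O)(=O)c2ccccc2F)cc1)C(F)(F)F` gives 1300 nM and compound 2 `Cc1ccccc1S(=O)(=O)c1ccc(NC(=O)C(C)(O)C(F)(F)F)cc1` gives 5100 nM. Both measured steps onto compound 3 concern the group on the sulfonyl sulfur: a 2.2-fold lower number from compound 1 to compound 3 (0.34 log units; beyond the scatter) and an 8.5-fold lower number from compound 2 to compound 3 (0.93 log units; beyond the scatter). Compound 4 `CC(O)(C(=O)Nc1ccc(S(=O)(=O)c2cncs2)cc1)C(F)(F)F` carries 1,3-thiazol-5-yl in place of pyridin-2-yl on a sulfonyl sulfur. Among the compounds with values here, no measured step exchanges one heteroaryl for another on that sulfur, so the two steps only show that this position tolerates change of modest size. The expected step in this assay is therefore small, a 1.3-fold higher number from compound 3 to compound 4 (0.12 log units; within the scatter), in either direction rather than a firm one. Compound 4 is estimated at 800 nM, within 300 nM to 2500 nM.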

Compound 4, half-maximal inhibitory concentration: 7700 nM
The estimate for compound 4 lay 9.6-fold (0.98 log units) below the measured number, outside the stated range (above it).
By their numbers in this assay, from the lowest: compound 3; then compound 1; then compounds 2 and 4 (each within the scatter of the next).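

In this assay, within the data shown here, the group on the sulfonyl sulfur can shift the number further than the earlier steps showed: a 13-fold higher number from compound 3 to compound 4 (1.11 log units; beyond the scatter) is the largest step in the set, and it joins two heteroaryl rings. The 1,3-thiazol-5-yl group does not track pyridin-2-yl, with a 5.9-fold higher number from compound 1 to compound 4 (0.77 log units; beyond the scatter) and a 1.5-fold higher number from compound 2 to compound 4 (0.18 log units; within the scatter), so the two heteroaryl groups here do not behave alike. No available evidence bears on the reason for this gap. Open, on these data alone, is how an unsubstituted phenyl, a pyrimidine ring, or a phenyl ring carrying an amine or a carboxylic acid would read on this sulfur.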